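Benzylamine in place of aniline on the shared core

A few compounds are considered here, and "the series" means these few. Any claim that something is new, unique, unknown or untested is made for them only; others in the source may bear on it.

compound 1 `CCCCCCn1cnc2c(Nc3cccc(Cl)c3)nc(N[C@H]3CC[C@H](N)CC3)nc21`: 2300 nM
compound 2 `CCCCn1cnc2c(Nc3cccc(Cl)c3)nc(N[C@H]3CC[C@H](N)CC3)nc21`: 2000 nM
compound 3 `N[C@H]1CC[C@H](Nc2nc(Nc3cccc(Cl)c3)c3ncn(Cc4ccccc4)c3n2)CC1`: 3000 nM

In a functional assay on K562 cells (Homo sapiens) for inhibition, read by fluorescence, with a stated time of 72 h (a higher number here means a weaker inhibitor of growth, a lower number a stronger inhibitor of growth), the three measured compounds sit close together. Compound 2 has the lowest number; compound 1 is nearest, a 1.2-fold lower number from compound 1 to compound 2 (0.06 log units; within the scatter), and compound 3 furthest, a 1.5-fold higher number from compound 2 to compound 3 (0.18 log units; within the scatter), while a 1.3-fold higher number from compound 1 to compound 3 (0.12 log units; within the scatter) completes the set. All three steps lie within the scatter, and each varies only the group on the saturated chain carbon bound to an aromatic nitrogen. Compound 4 `CCCCn1cnc2c(NCc3cccc(Cl)c3)nc(N[C@H]3CC[C@H](N)CC3)nc21` changes a different site: 3-chlorobenzyl in place of 3-chlorophenyl on a nitrogen on an aromatic ring. Among the compounds with values here, no measured step touches that nitrogen, so the data give no direction for it. The expectation for compound 4 is a step of a 1.5-fold higher number from compound 2 to compound 4 (0.18 log units; within the scatter), with wide uncertainty. Compound 4 is estimated at 3000 nM, between 800 nM and 12000 nM.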

Compound 4, concentration for 50% growth inhibition: 4300 nM
Estimate against measurement, compound 4: 1.4-fold (0.16 log units) below; the measured number falls inside the stated range.
By their numbers in this assay, from the lowest: compounds 2, 1, 3 and 4 (each within the scatter of the next, the first and the last beyond it).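

Within the data shown here, the nitrogen on an aromatic ring gives the first step beyond the scatter: in this assay, 3-chlorobenzyl in place of 3-chlorophenyl gives a 2.2-fold higher number from compound 2 to compound 4 (0.33 log units; beyond the scatter) as a modest rise. The group on the saturated chain carbon moved no number beyond the scatter across compounds 1, 2 and 3, whereas this site responds, towards weaker growth inhibition. Nothing available bears on the reason for this step.

Open, going by these compounds, is how this nitrogen responds to a longer link such as 2-phenylethyl. Also open, on these data alone, is whether a plain phenyl or benzyl without chlorine follows the same direction.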